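The source may report more compounds than this note shows. Statements on the series, on what has been measured and on what is new or still open speak of the compounds shown alone.

This account follows a single change made to compound 1 `CO[C@H]1O[C@@]2(C)CC(=O)[C@H]3C[C@]2(O[C@@H]2O[C@H](COC(=O)c4cc(O)c(O)c(O)c4)[C@@H](O)[C@H](O)[C@H]2O)[C@]13COC(=O)c1ccccc1` in a functional assay on N9 cells (Mus musculus) for inhibition, with N9 (Homo sapiens) as the target, read by Griess assay, with a stated time of 48 h; on this read-out higher numbers stand for weaker inhibition and lower numbers for stronger inhibition. Compound 1 gives 13900 nM in this assay, the lowest of the two numbers recorded, and compound 3 `C[C@@H]1CC(=O)[C@H]2C[C@]1(O)[C@]2(C)COC(=O)c1cc(O)c(O)c(O)c1` stands at 61800 nM, a gap wider than the scatter of repeated measurements. Compound 2 `COC1C[C@@]2(C)CC(=O)[C@@H]3C[C@]2(O[C@@H]2O[C@H](CO)[C@@H](O)[C@H](O)[C@H]2O)[C@@]13COC(=O)c1ccccc1` reaches only a limit of the assay, > 100000 nM, and no number. Going by the values given here, none of these three compounds differs from another in a single place, so no measured step can be read from them; the limit of > 100000 nM in this assay, at which 1 of the 3 values shown sits, is the only further evidence the set offers.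

Compound 4 `CO[C@H]1O[C@@]2(C)CC(=O)[C@H]3C[C@]2(O[C@@H]2O[C@H](COC(=O)c4ccccc4)[C@@H](O)[C@H](O)[C@H]2O)[C@]13COC(=O)c1ccccc1` differs from compound 1 in one place: phenyl in place of 3,4,5-trihydroxyphenyl on a carbonyl carbon. Compound 3 keeps the 3,4,5-trihydroxyphenyl ester and gives 61800 nM in this assay. Compound 2 lacks that ester altogether and reaches only the limit. Within this small set, then, the number has never been lower than that of compound 1 when the 3,4,5-trihydroxyphenyl ester was absent, though no single measured step shows this. The step is expected to go toward weaker inhibition, by an amount beyond the scatter, as a 2.9-fold higher number from compound 1 to compound 4 (0.46 log units; beyond the scatter). Compound 4 is therefore estimated at 40000 nM in this assay, with a range from 15000 nM to 100000 nM.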

Compound 4, half-maximal inhibitory concentration: 36200 nM
The estimate for compound 4 lay 1.1-fold (0.04 log units) above the measured number; low and high end bracket the measured number.
By their numbers in this assay, from the lowest: compound 1; then compounds 4 and 3 (each within the scatter of the next). At a limit, above all of these: compound 2.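

The replacement gives the set its first measured single-place step: in this assay, phenyl in place of 3,4,5-trihydroxyphenyl on a carbonyl carbon gives a 2.6-fold higher number from compound 1 to compound 4 (0.42 log units; beyond the scatter). The earlier compounds shown here could only hint at the importance of this group, since none of them differed from another in one place, whereas this pair isolates the change and shows that the step is modest, with compound 4 still giving a measured number instead of a limit. The ring stays aromatic and the ester link stays in place, so the step goes with the change from 3,4,5-trihydroxyphenyl to phenyl, though nothing shown here gives a cause for it.

The compounds shown leave open whether all the hydroxyl groups of the 3,4,5-trihydroxyphenyl group contribute to this step or only some, a question that a 4-hydroxyphenyl or a 3,4-dihydroxyphenyl group at this place would address. They also leave open how a 3,4,5-trimethoxyphenyl group, or a phenyl ring bearing an amine or a carboxylic acid, would read at this same place.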